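The source may report more compounds than this note shows. Statements on the series, on what has been measured and on what is new or still open speak of the compounds shown alone.

Compound 1 `COc1ccc(C(=O)c2cc(C)ccc2OCC(=O)NNC(=O)c2cc3ccccc3oc2=O)cc1` serves as the reference point. Among the measured compounds shown here, in a functional assay on DLA cells (Mus musculus) for cytotoxicity, read by MTT assay, with a stated time of 48 h (a lower number here means a stronger inhibitor, a higher number a weaker inhibitor), compound 1 gives 42000 nM, the lowest of the two numbers measured so far. Compound 2 `Cc1ccc(OCC(=O)NNC(=O)c2cc3ccccc3oc2=O)c(C(=O)c2ccc(Br)cc2)c1`, which carries bromo in place of methoxy on an aromatic carbon, gives 92200 nM in this assay; that step is a 2.2-fold higher number from compound 1 to compound 2 (0.34 log units; beyond the scatter). Compound 3 `Cc1ccc(OCC(=O)NNC(=O)c2cc3ccccc3oc2=O)c(C(=O)c2ccc(F)cc2)c1` has not yet been measured. It differs from compound 1 in this way: fluoro in place of methoxy on an aromatic carbon. For the measured compounds named here, the only measured step that bears on this change, a 2.2-fold higher number from compound 1 to compound 2 (0.34 log units; beyond the scatter), also put a halogen in place of the same methoxy, and the number moved up only modestly. For compound 3 a step of similar direction and comparable or smaller size is therefore expected in this assay, a 1.5-fold higher number from compound 1 to compound 3 (0.17 log units; within the scatter), possibly within the scatter. Compound 3 is estimated to give about 62000 nM in this assay, with a likely range from 33000 nM to 120000 nM.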

Compound 3, half-maximal inhibitory concentration: 43400 nM
Compound 3: the middle estimate sits 1.4-fold (0.15 log units) above what was measured; low and high end bracket the measured number.
By their numbers in this assay, from the lowest: compounds 1 and 3 (each within the scatter of the next); then compound 2.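

In this assay, the 4-fluorophenyl and 4-methoxyphenyl compounds cannot be told apart, with a 1.0-fold higher number from compound 1 to compound 3 (0.01 log units; within the scatter). Placing a halogen at this carbon, para to a large group, therefore does not by itself raise the number, which compound 2 alone could not show. The higher number belongs to bromo among the two halogens, with a 2.1-fold lower number from compound 2 to compound 3 (0.33 log units; beyond the scatter), and nothing available explains this gap.

On these data alone, it remains open how this position would respond to chloro, a hydroxyl group, an amine or a longer alkoxy chain such as ethoxy, and so whether bromo stands alone or marks a wider trend. As far as these compounds go, it is equally open whether the similar numbers of compound 1 and compound 3 would persist on changes elsewhere in the shared core.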